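From Compound 2 to Compound 3 in MOLT-4 Cells

This account rests on a few compounds, and the source may have more. Where it says the series, first, only, none or still open, it means among the compounds named here.

Measured compounds:
compound 1, `C=C(C)Cn1cc(/C=C/C(=O)CC(=O)C(=O)OCC)c2ccccc21`: "not determined" (no result reported)
compound 2, `C=C(C)Cn1cc(/C=C/C(=O)CC(=O)C(=O)O)c2ccccc21`: 40000 nM

Among the compounds with values here, compound 2 holds the only number in the set. Within the data shown here, in a functional assay on MOLT-4 cells (Homo sapiens) for inhibition, read by MTT assay, with a stated time of 48 h (on this read-out lower numbers stand for stronger inhibition and higher numbers for weaker inhibition), compound 2 gives 40000 nM, a weak effect, and compound 1 has no value at all, so no step between measured compounds can be read. Compound 3, `O=C(/C=C/c1cn(Cc2ccc(Cl)cc2)c2ccccc12)CC(=O)C(=O)O`, differs from compound 2 in one place: 4-chlorophenyl in place of 1-methylethenyl on a saturated chain carbon bound to an aromatic nitrogen. Among the measured compounds shown here, with a single number and no measured step to draw on, the size of the change from compound 2 to compound 3 in this assay cannot be anchored in the data; the expectation is a step of modest size toward stronger inhibition, though a step no larger than the usual scatter remains quite possible. Compound 3 is therefore expected to give 20000 nM in this assay, within a range from 5000 nM to 60000 nM, which means an expected step of a 2.0-fold lower number from compound 2 to compound 3 (0.30 log units; within the scatter).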

Compound 3, half-maximal inhibitory concentration: 19000 nM
Beside the measured number, compound 3's estimate is 1.1-fold (0.02 log units) above it, and the stated range covers the measured number.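

In this assay, within the data shown here, the place on a saturated chain carbon bound to an aromatic nitrogen gives the first readable step in this set: putting 4-chlorophenyl in place of 1-methylethenyl gives a 2.1-fold lower number from compound 2 to compound 3 (0.32 log units; beyond the scatter). Among these compounds, the position therefore accepts a group carrying a six-membered aromatic ring with a modest gain in inhibition, although the two compounds remain the only pair with numbers. No measurement shown accounts for this step.

From the compounds shown here alone, whether the ring or the chlorine carries the step remains open, as does the outcome with a plain benzyl, a 4-methoxybenzyl or an aminoethyl chain at this place. Going by these compounds, compound 1 stands at "not determined" (no result reported), so any step involving it cannot be read, and the effect of the ethyl ester in this assay remains unknown.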